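The source may report more compounds than this note shows. Statements on the series, on what has been measured and on what is new or still open speak of the compounds shown alone.

In an ADME assay on blood (Rattus norvegicus) for metabolic stability, with a stated time of 2 h (on this read-out higher numbers stand for a more stable compound and lower numbers for a less stable compound), compound 1 `CCc1ccc2oc(CSc3nnc(CNc4ccccc4)n3CC)nc2c1` has the entry "not determined" (no result reported) and offers no number for comparison. Among the measured compounds shown here, compound 2 `CCn1c(CNc2ccccc2)nnc1SCc1nc2cc(Cl)ccc2o1` gives 92% and holds the only number so far, which leaves it without a measured neighbour to be ranked against. Compound 3 `CCn1c(CNc2ccccc2)nnc1SCc1nc2cc(OC(F)(F)F)ccc2o1` is still unmeasured. Its structure departs from compound 2 at one place (trifluoromethoxy in place of chloro on an aromatic carbon) with trifluoromethoxy in place of chloro on an aromatic carbon. For the measured compounds named here, no measured pair shows what such a swap does in this assay and the only anchor for an expectation is compound 2 at 92% on its own. The expected a number 2 percentage points lower from compound 2 to compound 3 (within the scatter) is no shift beyond the usual scatter, in neither direction. Compound 3 is estimated at 90% with an expected range from 78% to 100% on this read-out.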

Compound 3, percent of the compound remaining: 100%
For compound 3 the middle estimate is 10 percentage points below the measured one, and the stated range covers the measured number.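

Putting trifluoromethoxy in place of chloro on this aromatic carbon gives a number 8 percentage points higher from compound 2 to compound 3 (within the scatter) in this assay. This first readable pair shows that the place, meta to a fused ring and para to a fused ring, accepts a group of 5 heavy atoms instead of a single chlorine with no shift beyond the usual scatter, so the two compounds cannot be told apart on this read-out. Nothing measured here offers an explanation for this result.

Steps involving compound 1 cannot be read, as it carries no number. From the compounds shown here alone, it also remains open whether an amine or a carboxylic acid at this same place would keep the compound as stable, and one swap cannot show how other groups would behave there.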